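Two Cores, One Methyl-to-Methoxy Swap, One Prediction

A few compounds are considered here, and "the series" means these few. Any claim that something is new, unique, unknown or untested is made for them only; others in the source may bear on it.

Measured so far in a functional assay on MCF7 cells (Homo sapiens) for inhibition, read by MTT assay, with a stated time of 48 h; a higher number here means a weaker inhibitor, a lower number a stronger inhibitor:
- compound 1, `Cc1ccc(-n2cc(NC(=O)c3cccc(NS(=O)(=O)c4ccc(Cl)cc4)c3)cn2)cc1`, gives 1080 nM
- compound 2, `COc1ccc(-n2cc(NC(=O)c3cccc(NS(=O)(=O)c4ccc(Cl)cc4)c3)cn2)cc1`, gives 8720 nM
- compound 3, `Cc1ccc(-n2cc(NC(=O)c3ccc(NS(=O)(=O)c4ccc(Cl)cc4)cc3)cn2)cc1`, gives 3990 nM

Compounds 1 and 2 share one core and differ in a single place: methoxy in place of methyl on an aromatic carbon. That change produced an 8.1-fold higher number from compound 1 to compound 2 (0.91 log units; beyond the scatter), a clear weakening.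

Compound 3 is built on a second core. How the two cores differ is not broken down here. In this assay compound 3 sits between the other two: its number is higher than that of compound 1 and lower than that of compound 2, both gaps being beyond the usual scatter.

Compound 4, `COc1ccc(-n2cc(NC(=O)c3ccc(NS(=O)(=O)c4ccc(Cl)cc4)cc3)cn2)cc1`, has not yet been measured. It stands to compound 3 exactly as compound 2 stands to compound 1: methoxy in place of methyl on an aromatic carbon. The place of the change reads the same in both pairs, so this is the same change carried onto the second core.

For the measured compounds named here, with only one earlier example of this change, the expectation rests on that single step. If the second core responds as the first did, compound 4 is expected to show a weakening of about a 6.3-fold higher number from compound 3 to compound 4 (0.80 log units; beyond the scatter), because the same change gave an 8.1-fold higher number from compound 1 to compound 2 (0.91 log units; beyond the scatter). Compound 4 is therefore estimated at 25000 nM, with a plausible range from 8000 nM to 80000 nM, the range being wide since one example is a thin basis.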

Compound 4, half-maximal inhibitory concentration: 15600 nM
Beside the measured number, compound 4's estimate is 1.6-fold (0.20 log units) above it; the measured number falls inside the stated range.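

On the second core, swapping methyl for methoxy again weakened the compound in this assay, with a 3.9-fold higher number from compound 3 to compound 4 (0.59 log units; beyond the scatter), so the direction of the change seen on the core of compound 1 carried over to the core of compound 3. The size of the step also cannot be told apart between the two cores, so the change behaves alike on both as far as these four compounds can show: the same change on two cores in this assay, an 8.1-fold higher number (0.91 log units; beyond the scatter) from compound 1 to compound 2 and a 3.9-fold higher number (0.59 log units; beyond the scatter) from compound 3 to compound 4, 2.1-fold (0.31 log units) apart, within the scatter of two such steps

For the compounds shown here, this does not make a general rule, since two pairs cover only two cores, one assay and one position, and the numbers say nothing about why methoxy gives the weaker compound in each pair.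

The compounds shown leave open whether the step from 4-methylphenyl to 4-methoxyphenyl would keep its direction on any further core, or in cells other than those tested here. They also leave open how other groups on the same aromatic carbon would compare with methyl and methoxy, for example an amine, a carboxylic acid or a longer chain such as ethoxy.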